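Capping a Phenol: From Compound 3 to Compound 4

The source may report more compounds than this note shows. Statements on the series, on what has been measured and on what is new or still open speak of the compounds shown alone.

Of the compounds shown here, three sharing one core have been measured in a functional assay on T47D cells (Homo sapiens) for cytotoxicity, read by CCK-8 assay and cell counting, with a stated time of 72 h; a lower number here means a stronger inhibitor, a higher number a weaker inhibitor. Compound 1 `COc1ccc(-c2cc3ccccc3c(-c3ccc(O)cc3)n2)cc1` gives 1220 nM. Compound 2 `COc1ccc(-c2cc3cc(C)ccc3c(-c3cccc(N)c3)n2)c(C)c1` gives 740 nM. Compound 3 `COc1ccc(-c2cc3cc(C)ccc3c(-c3cccc(O)c3)n2)cc1OC` gives 4340 nM, the highest of the three numbers, which makes it the weakest inhibitor of the set; compound 1 stands nearest to it and compound 2 furthest, and both gaps lie beyond the usual scatter of this assay.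

Compound 4 `COc1cccc(-c2nc(-c3ccc(OC)c(OC)c3)cc3cc(C)ccc23)c1` has not yet been measured. It is built from compound 3 by a single change: methyl in place of hydrogen on an oxygen on an aromatic ring. Among the compounds with values here, no measured pair of compounds differs in exactly this way, so the data hold no step that could simply be copied. Compound 1 and compound 2 carry other groups in place of this hydroxy and also differ from compound 3 elsewhere, so their values show only that a hydroxy is not needed for a lower number among these compounds. For the step in this assay no change beyond the scatter is expected, with the estimate leaning slightly toward a higher number a 1.1-fold higher number from compound 3 to compound 4 (0.04 log units; within the scatter). Compound 4 is therefore expected to give about 4800 nM, within a range from 1500 nM to 15000 nM.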

Compound 4, half-maximal inhibitory concentration: 7860 nM
For compound 4 the middle estimate is 1.6-fold (0.21 log units) below the measured one; measured number inside the range.
By their numbers in this assay, from the lowest: compounds 2 and 1 (each within the scatter of the next); then compounds 3 and 4 (each within the scatter of the next).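

In this assay, within the data shown here, the change from hydroxy to methoxy gives a 1.8-fold higher number from compound 3 to compound 4 (0.26 log units; within the scatter), and this is the first step that isolates a single change. It shows that, on this core, the hydrogen on this oxygen can give way to a methyl without a shift beyond the usual scatter, so a free hydroxy at this place is not needed to keep the number where compound 3 has it. The data shown offer no independent measurement that could account for this result.

This single pair cannot say how far the tolerance reaches: a longer chain on this oxygen, such as ethyl or benzyl, or a carboxylic acid at this place on the ring could still move the number well beyond the scatter. On these data alone, compound 1 also carries a hydroxy on an aromatic ring, and what a methyl on that oxygen would do, on a core that differs in other places, remains open as well.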